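This account rests on a few compounds, and the source may have more. Where it says the series, first, only, none or still open, it means among the compounds named here.

Working notes on the series. Compound 1 `CNC(=O)CSc1nc2ccc(NC(=O)c3ccc(Cl)cc3)cc2s1` is the reference point: in a functional assay on HepG2 cells (Homo sapiens) for cytotoxicity, read by MTT assay, with a stated time of 48 h (a lower number here means a stronger inhibitor, a higher number a weaker inhibitor), compound 1 gives 15300 nM. Compound 2 `CNC(=O)CSc1nc2ccc(NC(=O)c3ccccc3OC)cc2s1` keeps the same core and differs only in the aryl on the carbonyl carbon; in this assay compound 2 gives 18500 nM. The measured step is a 1.2-fold higher number from compound 1 to compound 2 (0.08 log units; within the scatter), so the two numbers lie within the usual scatter of each other and neither compound stands apart on the evidence so far.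

Compound 3 `COc1ccccc1C(=O)Nc1ccc2nc(SCC(=O)NCc3ccc(Cl)cc3)sc2c1` is not yet measured. Relative to compound 2 the change is 4-chlorophenyl in place of hydrogen on a saturated chain carbon bound to an amide-type nitrogen. For the measured compounds named here, no measured step concerns this part of the molecule: the only step in hand, a 1.2-fold higher number from compound 1 to compound 2 (0.08 log units; within the scatter), alters the aryl on the carbonyl carbon and is itself within the scatter. With nothing in the data that speaks for a change at the amide end, the expectation for compound 3 in this assay is a step of a 1.2-fold lower number from compound 2 to compound 3 (0.09 log units; within the scatter), that is, no step beyond the scatter in either direction. For compound 3 the estimate in this assay is therefore 15000 nM, with a range from 5000 nM to 45000 nM.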

Compound 3, half-maximal inhibitory concentration: 600 nM
For compound 3 the middle estimate is 25-fold (1.40 log units) above the measured one; the whole stated range lies above it.
By their numbers in this assay, from the lowest: compound 3; then compounds 1 and 2 (each within the scatter of the next).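

The amide end of the molecule proves to be a place where this assay responds strongly: 4-chlorophenyl in place of hydrogen on a saturated chain carbon bound to an amide-type nitrogen, which reads as methylcarbamoyl to (4-chlorobenzyl)carbamoyl, gives a 31-fold lower number from compound 2 to compound 3 (1.49 log units; beyond the scatter) in a single change. For the compounds shown here, the only earlier step, a 1.2-fold higher number from compound 1 to compound 2 (0.08 log units; within the scatter), concerned the aryl on the carbonyl carbon and stayed within the scatter, so this is the first change to move the number beyond it, and it sets compound 3 apart from compound 2. Nothing available bears on the reason for a step of this size.

As far as these compounds go, it remains open whether the 4-chloro substituent is needed at all, or whether an unsubstituted benzyl, a 4-methoxybenzyl, a longer 2-phenylethyl chain, a plain butyl chain, an amine or a carboxylic acid at this place would give a similar number. Also open, from the compounds shown here alone, is whether the same change gives a step of similar size with 4-chlorophenyl on the carbonyl carbon, as in compound 1, since this change has been read only with the 2-methoxyphenyl group in place.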